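The compounds below may be only part of what the source reports. "The series", "measured", "known", "first", "only" and "open" are said of these compounds alone.

Measured compounds:

Compound 1 `O=c1[nH]cnc2c1c(-c1ccco1)cn2[C@@H]1O[C@H](CO)[C@@H](O)[C@H]1O`: in a functional assay on A549 cells (Homo sapiens), read by MTT assay, with a stated time of 72 h (a higher number here means a weaker inhibitor, a lower number a stronger inhibitor), compound 1 gives > 20000 nM, which is a limit of the assay and not a number.
Compound 2 `O=c1[nH]cnc2c1c(-c1cc3ccccc3o1)cn2[C@@H]1O[C@H](CO)[C@@H](O)[C@H]1O`: in this assay compound 2 gives > 20000 nM, again a limit and not a number.
Compound 3 `CNc1ncnc2c1c(-c1cc3ccccc3o1)cn2[C@@H]1O[C@H](CO)[C@@H](O)[C@H]1O`: in this assay compound 3 gives > 20000 nM, also a limit and not a number.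

Compound 4 `CNc1ncnc2c1c(-c1ccco1)cn2[C@@H]1O[C@H](CO)[C@@H](O)[C@H]1O` has not yet been measured in this assay. It differs from compound 3 by one change (furan-2-yl in place of 1-benzofuran-2-yl on an aromatic carbon). The same change is made from compound 2 to compound 1 (furan-2-yl in place of 1-benzofuran-2-yl on an aromatic carbon), and the two "place" descriptions agree word for word, so this is the same change made on two cores. How the core of compound 3 differs from the core of compound 2 is not broken down here.

Going by the values given here, the only measured instance of the change, a step that the two limits leave unreadable from compound 2 to compound 1, cannot be read in size, since both ends of it sit at the assay limit. Among the compounds with values here, the whole picture of the series so far is the limit of > 20000 nM in this assay, at which 3 of the 3 values shown sit, and that is the sole ground for any expectation about compound 4.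

Given that, the step from compound 3 to compound 4 is expected to be a step that the limit leaves unreadable from compound 3 to compound 4, that is, no readable step at all. Compound 4 is expected to give 30000 nM in this assay, most likely again as a limit rather than a number, with a range of 10000 nM to 100000 nM should a number be obtained.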

Compound 4, half-maximal inhibitory concentration: 2570 nM
Beside the measured number, compound 4's estimate is 12-fold (1.07 log units) above it; measured number below the stated range.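

On the core of compound 3, furan-2-yl in place of 1-benzofuran-2-yl gives an at least 7.7-fold lower number from compound 3 to compound 4 (0.89 log units; beyond the scatter) in this assay, and this size is only a minimum, as the starting end of the step is a limit and not a number. The same change on the core of compound 2 cannot be read in size, with compound 1 and compound 2 both at a limit, so this single readable instance neither shows nor rules out that the change carries from one core to the other. Compound 4 is the only compound here with a readable number, and the rest of the set gives no size to compare it with: the limit of > 20000 nM in this assay, at which 3 of the 4 values shown sit.

Left open is whether the step on the core of compound 3 is specific to furan-2-yl, or whether a smaller or different aromatic group such as thiophene-2-yl or phenyl would give a readable number on that core too. Also open, on these data alone, is how the number of compound 4 would respond if the methylamino group gave way to a free amine, a dimethylamino group or a longer chain such as propylamino.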